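From a Large Aromatic Group to a Single Methyl

The compounds below may be only part of what the source reports. "The series", "measured", "known", "first", "only" and "open" are said of these compounds alone.

In a functional assay on MDA-MB-231 cells (Homo sapiens) for inhibition, read by MTT assay, with a stated time of 48 h (a higher number here means a weaker inhibitor of growth, a lower number a stronger inhibitor of growth), compound 1 `Oc1ccc(NC(=S)Nc2ccc3ncnc(Nc4cccc(Br)c4)c3c2)cc1` gives 17300 nM and compound 2 `FC(F)(F)c1ccc(NC(=S)Nc2ccc3ncnc(Nc4cccc(Br)c4)c3c2)cc1` gives 12200 nM. These two numbers lie within the scatter of each other, so compound 2 cannot be separated from compound 1. Within the data shown here, only one measured step bears on what comes next: a 1.4-fold lower number from compound 1 to compound 2 (0.15 log units; within the scatter), with trifluoromethyl in place of hydroxy on an aromatic carbon, and it stays within the scatter. Compound 3 `CNC(=S)Nc1ccc2ncnc(Nc3cccc(Br)c3)c2c1` carries a far bigger structural change: methyl in place of 4-(trifluoromethyl)phenyl on an amide-type nitrogen. Here methyl replaces 4-(trifluoromethyl)phenyl on an amide-type nitrogen, so the whole aromatic ring leaves. Among the measured compounds shown here, the measured step kept that ring in place, and no measured compound lacks it, so the data offer only weak guidance. The expected step, a 1.6-fold higher number from compound 2 to compound 3 (0.21 log units; within the scatter), is small and leans toward a higher number, meaning a weaker inhibitor, with real uncertainty in both size and direction. In this assay, the estimate for compound 3 is 20000 nM, with an expected range from 7000 nM to 50000 nM.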

Compound 3, concentration for 50% growth inhibition: > 30000 nM
Compound 3: only a limit was reported (the forecaster's own chance of this, stated with the estimate: 10%); at least 1.5-fold (0.17 log units) between middle value and limit.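

Among these compounds, the earlier change altered a group on the aromatic ring and stayed within the scatter, whereas removing the ring on this amide-type nitrogen, with methyl in place of 4-(trifluoromethyl)phenyl, gives the first change beyond the scatter in this assay: an at least 2.4-fold higher number from compound 2 to compound 3 (0.39 log units; beyond the scatter). Methyl in place of 4-hydroxyphenyl gives an at least 1.7-fold higher number from compound 1 to compound 3 (0.23 log units; that floor lies within the scatter), so this floor alone does not separate the two compounds, although the true gap could be larger. Compound 3 carries only a limit, not a number, so both steps have a floor and no upper end: the limit of > 30000 nM in this assay, at which 1 of the 3 values shown sits.

As far as these compounds go, it remains open whether the aromatic ring itself matters or whether another group on this nitrogen could take its place, such as a longer chain like butyl, a cyclohexyl ring or a benzyl group. The compounds shown also leave open whether an amine or a carboxylic acid on the retained phenyl ring would move the number beyond the scatter in this assay.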